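A few compounds are considered here, and "the series" means these few. Any claim that something is new, unique, unknown or untested is made for them only; others in the source may bear on it.

Compound 1 `COc1ccc(NNS(=O)(=O)c2ccc(NC(C)=O)cc2)cc1` carries an acetamido group on one ring and a methoxy group on the other. In an assay on HeLa cells for inhibition of Indoleamine 2,3-dioxygenase 1 (Homo sapiens), read by spectrophotometry, with a stated time of 24 h (a lower number here means that less compound is needed, a higher number that more compound is needed for the effect), compound 1 reaches only a limit of the assay, > 10000 nM. Compound 2 `O=S(=O)(NNc1ccc(Br)cc1)c1ccccc1` is the plainer sulfonyl hydrazide, with a bromine on one ring and nothing on the other. In this assay compound 2 gives 128 nM. Among the compounds with values here, that is the only real number among the two values shown; the other entry is the limit of > 10000 nM in this assay, at which 1 of the 2 values shown sits, so compound 2 stands alone as the measured point. Compound 1 and compound 2 differ in more than one place, and together they show no more than that one gives a number and the other a limit.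

Compound 3 `COC(=O)CCc1ccc(S(=O)(=O)NNc2ccc(Br)cc2)cc1` keeps everything of compound 2 and adds one group: 2-(methoxycarbonyl)ethyl in place of hydrogen on an aromatic carbon. Within the data shown here, no measured pair here tracks such an addition, so the step can only be guessed. The expected step is a 2.0-fold higher number from compound 2 to compound 3 (0.29 log units; within the scatter), a modest move toward needing more compound that may stay within the usual scatter. For compound 3 the estimate is 250 nM, with a range from 60 nM to 1500 nM.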

Compound 3, half-maximal effective concentration: 465 nM
Compound 3: middle estimate off by 1.9-fold (0.27 log units), on the low side; measured number inside the range.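

Within the data shown here, the newest pair is the first measured one that differs in only one place, so the effect of a single change can now be read directly: in this assay, putting 2-(methoxycarbonyl)ethyl in place of hydrogen on an aromatic carbon, para to a large group, gives a 3.6-fold higher number from compound 2 to compound 3 (0.56 log units; beyond the scatter). This step is modest but lies beyond the usual scatter, which shows that this position accepts the added chain at a real cost in the amount of compound needed, while the result remains a measured number and not a limit of the assay. Nothing among the data shown explains why the number moves in this direction.

With only one group shown at this position, it remains open whether a shorter chain, a longer chain, an amine or a carboxylic acid in place of the methyl ester would give a smaller or larger step. Going by these compounds, compound 1 stands at a limit of the assay, > 10000 nM, and its acetamido and methoxy groups have not been separated, so what either one contributes also stays open.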